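The source may hold more compounds than are shown below. What is called first, only, known or untested is meant among the compounds shown, and "the series" means these compounds.

Of the compounds shown here, three of a shared core have been measured in an assay on HEK293 cells for inhibition of sodium- and chloride-dependent glycine transporter 1 (Homo sapiens), read by scintillation proximity assay (on this read-out higher numbers stand for weaker inhibition and lower numbers for stronger inhibition), and a fourth awaits its number.

Compound 1 `O=C(CN(Cc1ccc(Cl)cc1)C1CCCCC1)Nc1cc(F)cc(F)c1` reaches only the limit of this assay, giving > 25100 nM, which is a limit and not a number. Compound 2 `O=C(CN(C(=O)c1ccccc1Cl)C1CCCCC1)Nc1cc(F)cc(F)c1` gives 20000 nM in this assay. For the measured compounds named here, the single step between them, an at least 1.2-fold lower number from compound 1 to compound 2 (0.09 log units; that floor lies within the scatter), is too small to count as a change. Compound 3 `O=C(CN(CC1CC1)C(=O)c1ccc(-c2ccccn2)cc1)Nc1cc(F)cc(F)c1` gives 200 nM, the lowest of the numbers shown; compared with compound 2 its number is lower, a gap beyond the scatter.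

Compound 4 `O=C(CN(CC1CCC1)C(=O)c1ccc(-c2ccccn2)cc1)Nc1cc(F)cc(F)c1` differs from compound 3 in one place: cyclobutyl in place of cyclopropyl on a saturated chain carbon bound to an amide-type nitrogen. No measured step touches this part of the molecule, so the only step shown, from compound 1 to compound 2, gives no guidance on it. Without such evidence the change is expected to leave the number about where it is, and the step of a 1.3-fold higher number from compound 3 to compound 4 (0.10 log units; within the scatter) is estimated to stay within the scatter. Compound 4 is therefore expected to give 250 nM, with a range from 100 nM to 630 nM.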

Compound 4, half-maximal inhibitory concentration: 126 nM
Compound 4: the middle estimate sits 2.0-fold (0.30 log units) above what was measured, within the range that was stated.
By their numbers in this assay, from the lowest: compounds 4 and 3 (each within the scatter of the next); then compound 2. At a limit, above all of these: compound 1.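

Replacing cyclopropyl with cyclobutyl on a saturated chain carbon bound to an amide-type nitrogen gives a 1.6-fold lower number from compound 3 to compound 4 (0.20 log units; within the scatter) in this assay, so compound 3 and compound 4 cannot be told apart on this read-out. This is the first step shown at this position, and it shows that a four-membered carbon ring can stand in place of a three-membered one without leaving the scatter. No measurement shown bears on what lies behind this result.

The compounds shown leave open how far this tolerance extends, for instance whether a cyclopentyl or cyclohexyl ring, or an open butyl chain, would stay in the same range. As far as these compounds go, it is also open whether a ring carrying an amine or a hydroxyl group would fit here.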